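Lengthening the Chain of an Inactive Compound

This account rests on a few compounds, and the source may have more. Where it says the series, first, only, none or still open, it means among the compounds named here.

Measured in a functional assay on SK-OV-3 cells (Homo sapiens) for cytotoxicity, read by MTT assay, with a stated time of 24 h; a higher number here means a weaker inhibitor, a lower number a stronger inhibitor:
- Compound 1 `CCCCCCCCCCCC(=O)Nc1nnc(S[C@@H]2O[C@H](COC(C)=O)[C@H](OC(C)=O)[C@H](OC(C)=O)[C@H]2OC(C)=O)s1`: "not active" (no number reported)
- Compound 2 `CCCCCCCC(=O)Nc1nnc(S[C@@H]2O[C@H](CO)[C@H](O)[C@H](O)[C@H]2O)s1`: 56000 nM

Compound 1 has no single number to stand on. Its result is a plain verdict of "not active" (no number reported), so it cannot be placed on a scale. Going by the values given here, the only number available comes from compound 2, at 56000 nM.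

Compound 3 `CCCCCCCCCCCCCCCCCC(=O)Nc1nnc(S[C@@H]2O[C@H](COC(C)=O)[C@H](OC(C)=O)[C@H](OC(C)=O)[C@H]2OC(C)=O)s1` has not yet been measured. The structural change is hexyl in place of hydrogen on a saturated chain carbon, ten or more bonds along the chain from a carbonyl carbon.

Among the compounds with values here, no measured step shows what this kind of change does in this assay, so its size can only be judged. Compound 1 gives "not active" (no number reported), and this is the starting point, so I expect no move towards stronger inhibition beyond the usual scatter. It is quite possible that compound 3 will also return no number. If a number does appear, it is expected to be a weak result, on the scale of compound 2 or weaker.

The estimate for compound 3 is 100000 nM, with an expected range from 30000 nM to 300000 nM.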

Compound 3, half-maximal inhibitory concentration: "not active" (no number reported)
The entry for compound 3 holds no number; no gap can be computed for the estimate.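

In this assay compound 1 gives "not active" (no number reported) and compound 3 gives "not active" (no number reported), so with no number on either side, no step can be read between them. Nothing measured here offers an explanation for this result. The compounds shown leave open whether adding hexyl to the chain changes activity to any measurable extent.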